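This account rests on a few compounds, and the source may have more. Where it says the series, first, only, none or still open, it means among the compounds named here.

Measured compounds:
- compound 1 `Cc1nn(C)c(Oc2ccccc2F)c1/C=N\CCCCCCOc1cc2oc(=O)cc(C)c2cc1Cl`; in a functional assay on HepG2 cells (Homo sapiens) for antiproliferative activity, read by MTT assay, with a stated time of 72 h (a lower number here means a stronger inhibitor, a higher number a weaker inhibitor), compound 1 gives only the assay limit > 25000 nM.
- compound 2 `Cc1nn(C)c(Oc2ccc(F)cc2F)c1/C=N\CCCCCCOc1cc2oc(=O)cc(C)c2cc1Cl`; in this assay compound 2 gives only the assay limit > 25000 nM.
- compound 3 `Cc1nn(C)c(Oc2ccc(F)c(F)c2)c1/C=N\CCCCCCOc1cc2oc(=O)cc(C)c2cc1Cl`; in this assay compound 3 gives only the assay limit > 25000 nM.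

Compound 3 therefore stands where every measured compound stands: at the limit of > 25000 nM in this assay, at which 3 of the 3 values shown sit, so no number for it is known, only that it lies beyond what the assay can read. The steps among the measured compounds are likewise unreadable: a step that the two limits leave unreadable from compound 1 to compound 2, a step that the two limits leave unreadable from compound 1 to compound 3 and a step that the two limits leave unreadable from compound 2 to compound 3. Compound 4 `Cc1nn(C)c(Oc2ccc(Cl)cc2)c1/C=N\CCCCCCOc1cc2oc(=O)cc(C)c2cc1Cl` differs from compound 3 in one place: 4-chlorophenyl in place of 3,4-difluorophenyl on an oxygen on an aromatic ring. Going by the values given here, none of the measured steps gives a readable size, so no direction beyond the scatter can be expected for this assay from this change. The step from compound 3 to compound 4 is thus expected to be a step that the limit leaves unreadable from compound 3 to compound 4. For compound 4 the estimate in this assay is 40000 nM, ranging from 12000 nM to 150000 nM, most likely reported again as a limit.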

Compound 4, half-maximal inhibitory concentration: 2960 nM
Compound 4: the middle estimate sits 14-fold (1.13 log units) above what was measured; measured number below the stated range.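

In this assay, the group on the oxygen on an aromatic ring turns out to matter, which the fluorinated compounds alone could not show: the change to 4-chlorophenyl gives an at least 8.4-fold lower number from compound 3 to compound 4 (0.92 log units; beyond the scatter). The same kind of change gives an at least 8.4-fold lower number from compound 2 to compound 4 (0.92 log units; beyond the scatter) and also an at least 8.4-fold lower number from compound 1 to compound 4 (0.92 log units; beyond the scatter), and each of these sizes is a minimum rather than an exact figure, while the steps among compounds 1, 2 and 3 cannot be read. Compound 4 is the only one of the four that leaves the assay limit: the limit of > 25000 nM in this assay, at which 3 of the 4 values shown sit.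

Compound 4 both carries a chlorine and lacks fluorine, so the two changes cannot be separated here. On these data alone, how an unsubstituted phenyl, a 4-bromophenyl or a 4-methoxyphenyl would behave at this place remains open.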